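The source may report more compounds than this note shows. Statements on the series, on what has been measured and on what is new or still open speak of the compounds shown alone.

Measured so far in a physicochemical assay for solubility, using the shake flask method, in simulated intestinal fluid, measured as kinetic solubility, with a stated time of 2 h, at 25 degrees C, at pH 6.5 (a higher number here means a more soluble compound, a lower number a less soluble compound), all three entries being limits of the assay and not numbers:

Compound 1 `Cc1noc(-c2nc(C)c3c(c2N)C(=O)N(Cc2ccc(-n4cccn4)cc2)C3=O)n1` gives < 5000 nM
Compound 2 `Cc1noc(-c2nc(C)c3c(c2N)C(=O)N(Cc2ccc(Cl)cc2)C3=O)n1` gives < 5000 nM
Compound 3 `Cc1noc(-c2nc(C)c3c(c2N)C(=O)N(Cc2cccc(C(F)(F)F)c2)C3=O)n1` gives < 5000 nM

Compound 2 has no number of its own, only the limit < 5000 nM. The same holds across the set, as shown by the limit of < 5000 nM in this assay, at which 3 of the 3 values shown sit.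

Compound 4 `Cc1noc(-c2nc(C)c3c(c2N)C(=O)N(C(C)c2ccccc2)C3=O)n1` is not yet measured. It differs from compound 2 on an amide-type nitrogen in a ring, with 1-phenylethyl in place of 4-chlorobenzyl on an amide-type nitrogen in a ring. Both groups carry one six-membered aromatic ring of carbon only and no net charge.

Among the measured compounds shown here, two measured steps bear on this change, as both alter the group on that nitrogen. For the measured compounds named here, the first is a step that the two limits leave unreadable from compound 1 to compound 2 and the second is a step that the two limits leave unreadable from compound 2 to compound 3. Neither has a readable size, so neither offers a measured size or direction to carry over.

In this assay, no step beyond the scatter is expected, and no direction is expected either. The estimated step is a step that the limit leaves unreadable from compound 2 to compound 4. This expectation rests on compound 2 , whose limit is < 5000 nM, and a further limit is the likely reading. For compound 4 the estimate is 3000 nM, with an expected range from 1000 nM to 6000 nM.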

Compound 4, solubility: 10900 nM
The estimate for compound 4 lay 3.6-fold (0.56 log units) below the measured number; measured number above the stated range.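

In this assay, among the compounds shown here, 1-phenylethyl in place of 4-chlorobenzyl on the amide-type nitrogen in a ring gives the first readable step at this position: an at least 2.1-fold higher number from compound 2 to compound 4 (0.33 log units; beyond the scatter). The earlier steps among compound 1, compound 2 and compound 3 cannot be read, so this nitrogen had so far shown neither a size nor a direction, and the new step now gives a direction for one change, with the heavy-atom count, the single six-membered aromatic ring of carbon only and the absence of net charge all the same in the leaving and entering groups. Compound 4 is also the only compound here with a number and not a limit, so the rest of the set still gives no measured values to rank against it: the limit of < 5000 nM in this assay, at which 3 of the 4 values shown sit.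

The step from compound 2 to compound 4 swaps the chlorine and the benzyl chain for 1-phenylethyl in one move, and the compounds shown cannot say which part goes with the higher number, a question that plain benzyl on that nitrogen would separate. As far as these compounds go, how an amine or a carboxylic acid on the aromatic ring of that group would read in this assay also stays open.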